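A few compounds are considered here, and "the series" means these few. Any claim that something is new, unique, unknown or untested is made for them only; others in the source may bear on it.

Compound 1, `CC(C)Cc1ccc(C(C)c2nn(CN3CCN(c4ccc([N+](=O)[O-])cc4)CC3)c(=S)o2)cc1`, gives 75.1% in a functional assay on the whole organism (strain Wister albino) for inhibition, with Rattus norvegicus as the target, read by paw edema, with stated times of 30 min and 3 h, at a dose of 10 mg/kg by the oral route; a higher number here means more inhibition at the dose given (going by the name of the read-out), a lower number less inhibition.
Compound 2, `CC(C)Cc1ccc(C(C)c2nn(CN3CCN(c4ccc(F)cc4)CC3)c(=S)o2)cc1`, gives 75.4%.
Compound 3, `CSc1ccc(Cc2nn(CN3CCN(c4ccc([N+](=O)[O-])cc4)CC3)c(=S)o2)cc1`, gives 56.6%.

Compound 1 and compound 2 differ by fluoro in place of nitro on an aromatic carbon, and this step gave a number 0.3 percentage points higher from compound 1 to compound 2 (within the scatter). Compound 3 stands lowest of the three, beyond the scatter from both of the others. The difference between the core of compound 3 and the core of compound 1 is not broken down here. Compound 4, `CSc1ccc(Cc2nn(CN3CCN(c4ccc(F)cc4)CC3)c(=S)o2)cc1`, is still to be measured. It differs from compound 3 by fluoro in place of nitro on an aromatic carbon, which is the same change, at the same place, as that from compound 1 to compound 2. For compound 4 the expected step is a number 0.4 percentage points higher from compound 3 to compound 4 (within the scatter), because a number 0.3 percentage points higher from compound 1 to compound 2 (within the scatter) left the read-out essentially where it was. Compound 4 is therefore estimated at 57%, expected to fall between 47% and 67%.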

Compound 4, a percentage reported as inhibition, in the whole organism at one dose (the size of the read-out at that dose, not a potency): 68.7%
Estimate against measurement, compound 4: 11.7 percentage points below; the whole stated range lies below it.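

In this assay, fluoro in place of nitro gave a number 12.1 percentage points higher from compound 3 to compound 4 (beyond the scatter), set beside a number 0.3 percentage points higher from compound 1 to compound 2 (within the scatter) on the other core. Although only the first of these steps lies beyond the scatter, the two cannot be told apart: the same change on two cores in this assay, a number 0.3 percentage points higher (within the scatter) from compound 1 to compound 2 and a number 12.1 percentage points higher (beyond the scatter) from compound 3 to compound 4, 11.8 percentage points apart, within the scatter of two such steps. The pairs therefore show no evidence that the core alters the outcome of this change, but they do not show that its effect is the same on both cores, and two pairs are too few to settle the point.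

The compounds shown leave open how other groups at this place would read, such as an amine, a nitrile or a carboxylic acid. They also leave open whether any such group would behave alike on both cores.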